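A few compounds are considered here, and "the series" means these few. Any claim that something is new, unique, unknown or untested is made for them only; others in the source may bear on it.

Compound 1, with the structure `COc1cc(C(=O)NC2CCN(C)CC2)ccc1Nc1ncc(Cl)c(NC2CCCC2)n1`, and compound 2, with the structure `CN1CCC(NC(=O)c2ccc(Nc3ncc(F)c(NC4CCCC4)n3)cc2)CC1`, were both tested in a functional assay on HepG2 cells (Homo sapiens) for cytotoxicity, read by MTT assay, with a stated time of 48 h; a higher number here means a weaker inhibitor, a lower number a stronger inhibitor. In this assay compound 1 gives 9300 nM, and compound 2 gives 10000 nM. These two numbers sit within the usual scatter of each other, so on the figures shown compound 2 stands level with compound 1 rather than apart from it.

Compound 3, with the structure `COc1cc(C(=O)NC2CCN(C)CC2)ccc1Nc1ncc(F)c(NC2CCCC2)n1`, has not yet been measured in this assay. It differs from compound 2 in a single respect: methoxy in place of hydrogen on an aromatic carbon. Among the compounds with values here, no pair of measured compounds differs by exactly this change, so the step cannot be read straight from the numbers. What is known is that compound 1 already carries this methoxy group and gives 9300 nM, a number within the scatter of compound 2.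

On that basis the step of a 1.1-fold lower number from compound 2 to compound 3 (0.02 log units; within the scatter) is expected to stay within the scatter, with no clear direction. Compound 3 is therefore estimated at 9500 nM, with a range from 4000 nM to 22000 nM.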

Compound 3, half-maximal inhibitory concentration: 4500 nM
Estimate against measurement, compound 3: 2.1-fold (0.32 log units) above, within the range that was stated.
By their numbers in this assay, from the lowest: compound 3; then compounds 1 and 2 (each within the scatter of the next).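

In this assay, methoxy in place of hydrogen on an aromatic carbon, ortho to a large group and meta to a (1-methylpiperidin-4-yl)carbamoyl group, gives a 2.2-fold lower number from compound 2 to compound 3 (0.35 log units; beyond the scatter), so with fluoro on the core this position responds to the change, though the step is modest. The halogen also counts: with methoxy present, fluoro in place of chloro on an aromatic carbon gives a 2.1-fold lower number from compound 1 to compound 3 (0.32 log units; beyond the scatter), again a modest step, and the earlier pair could not show either effect alone since it differs in two places at once. Nothing measured here explains why either change lowers the number.

As far as these compounds go, whether methoxy gives a similar step with chloro on the core stays open, since these two steps come from a single set of three compounds and both end at compound 3. From the compounds shown here alone, it is also open how other groups at the same aromatic carbon, such as ethoxy, a hydroxyl or an amine, or other halogens such as bromo in place of fluoro, would shift the number.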